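Bis(trifluoromethyl)benzenesulfonamides: chloro for trifluoromethyl

The source may hold more compounds than are shown below. What is called first, only, known or untested is meant among the compounds shown, and "the series" means these compounds.

Measured compounds:
compound 1 `O=S(=O)(NCCNCc1ccc(-c2ccccc2)cc1)c1cc(C(F)(F)F)cc(C(F)(F)F)c1`, 2400 nM
compound 2 `O=S(=O)(NCCCNCc1ccc(C(F)(F)F)cc1)c1cc(C(F)(F)F)cc(C(F)(F)F)c1`, 2000 nM
compound 3 `CC(C)(C)c1ccc(CNCCNS(=O)(=O)c2cc(C(F)(F)F)cc(C(F)(F)F)c2)cc1`, 13000 nM

Within the data shown here, in a functional assay on Capan-2 cells (Homo sapiens) for inhibition, read by MTT assay, with a stated time of 72 h (on this read-out higher numbers stand for weaker inhibition of growth and lower numbers for stronger inhibition of growth), compound 2 gives 2000 nM, the lowest of the three numbers; its gap to compound 1 lies within the scatter, while compound 3 sits clearly higher, as a 5.4-fold higher number from compound 1 to compound 3 (0.73 log units; beyond the scatter) shows for the only single-point step among the measured compounds.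

The unmeasured compound 4 `O=S(=O)(NCCCNCc1ccc(Cl)cc1)c1cc(C(F)(F)F)cc(C(F)(F)F)c1` differs from compound 2 in one place: chloro in place of trifluoromethyl on an aromatic carbon. Among the measured compounds shown here, no measured pair shows exactly this exchange. For the measured compounds named here, the one step that bears on it at all is a 5.4-fold higher number from compound 1 to compound 3 (0.73 log units; beyond the scatter), where a change of the group on the distal aromatic ring moved the number by a modest amount; it concerns different groups, so it sets only the rough scale of what a change at that ring can do. A chloro group is a smaller substituent than trifluoromethyl, and the measured data give no direct guide to the direction.

Compound 4 is therefore expected to show a 1.5-fold higher number from compound 2 to compound 4 (0.18 log units; within the scatter) in this assay, a small shift that may fall within the scatter. The estimate for compound 4 is 3000 nM, with a range from 1200 nM to 8000 nM.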

Compound 4, concentration for 50% growth inhibition: 2700 nM
Compound 4: the middle estimate sits 1.1-fold (0.05 log units) above what was measured; low and high end bracket the measured number.
By their numbers in this assay, from the lowest: compounds 2, 1 and 4 (each within the scatter of the next); then compound 3.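

In this assay, among these compounds, chloro in place of trifluoromethyl on the aromatic carbon para to a large group gives a 1.4-fold higher number from compound 2 to compound 4 (0.13 log units; within the scatter), which is the first direct reading of this exchange and does not separate the two compounds. The 4-(trifluoromethyl)benzyl and 4-chlorobenzyl forms therefore cannot be told apart here, although 4 heavy atoms leave and 1 enters, whereas tert-butyl in place of phenyl on the compounds with a different linking chain gave a 5.4-fold higher number from compound 1 to compound 3 (0.73 log units; beyond the scatter), a step beyond the scatter. Nothing available here explains why this exchange leaves the two compounds within the scatter of each other.

On these data alone, it remains open whether a fluoro, a methoxy, a nitrile or a carboxylic acid at this place would also stay within the scatter of trifluoromethyl and chloro. The compounds shown also leave open what a longer or shorter chain contributes when the group on the distal ring is held constant, and whether chloro in place of trifluoromethyl would give a similar step on another chain.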